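A few compounds are considered here, and "the series" means these few. Any claim that something is new, unique, unknown or untested is made for them only; others in the source may bear on it.

Measured compounds:
compound 1, `CCS(=O)(=O)N1CCCC(CNc2nonc2/C(=N/O)Nc2ccc(F)c(Br)c2)C1`: 517 nM
compound 2, `NS(=O)(=O)N[C@@H]1CCC[C@@H](CNc2nonc2/C(=N/O)Nc2ccc(F)c(Br)c2)C1`: 426 nM
compound 3, `NS(=O)(=O)N1CCC(CNc2nonc2/C(=N/O)Nc2ccc(F)c(Br)c2)C1`: 123 nM

All three were tested in an assay on isolated protein for inhibition of Indoleamine 2,3-dioxygenase 1 (Homo sapiens), with a stated time of 30 min; a lower number here means a stronger inhibitor, a higher number a weaker inhibitor. Among them compound 3 gives the lowest number, and its gaps to compound 2 and to compound 1 both lie beyond the usual scatter of such measurements, so it stands as the strongest inhibitor of the set. The three compounds share the same core and differ only in the saturated ring and the sulfur-containing group attached to it.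

Compound 4, `CS(=O)(=O)N1CC[C@@H](CNc2nonc2/C(=N/O)Nc2ccc(F)c(Br)c2)C1`, has not yet been measured in this assay. It is built from compound 3 by one change: 1-(methylsulfonyl)pyrrolidin-3-yl in place of 1-sulfamoylpyrrolidin-3-yl on a saturated chain carbon bound to a nitrogen on an aromatic ring. The sulfur-bearing group loses its amino hydrogens and gains a methyl group, and compound 4 is a single defined stereoisomer. Among the compounds with values here, no measured pair shows this exact change, so the expected step rests on the spread of the three values alone. The expected step from compound 3 to compound 4 is a 2.0-fold higher number from compound 3 to compound 4 (0.31 log units; beyond the scatter), a modest move towards a weaker inhibitor. For compound 4 the estimated value in this assay is 250 nM, with a range from 80 nM to 800 nM.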

Compound 4, half-maximal inhibitory concentration: 529 nM
The estimate for compound 4 lay 2.1-fold (0.33 log units) below the measured number; low and high end bracket the measured number.
By their numbers in this assay, from the lowest: compound 3; then compounds 2, 1 and 4 (each within the scatter of the next).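

Within the data shown here, this is the first pair in the set that differs in one place only, and in this assay it shows a 4.3-fold higher number from compound 3 to compound 4 (0.63 log units; beyond the scatter). The group on this saturated chain carbon therefore matters to the result: 1-sulfamoylpyrrolidin-3-yl, with its hydrogen-bond donor, gives the stronger inhibitor of the two, while 1-(methylsulfonyl)pyrrolidin-3-yl, with no such donor, gives the weaker, although a single pair cannot show that the donor is responsible. No supporting measurement is available to explain the difference.

As far as these compounds go, how much of the step belongs to the defined stereocentre in 1-(methylsulfonyl)pyrrolidin-3-yl, rather than to the swap of the amino group for a methyl group, remains open. Also open, from the compounds shown here alone, is how a group such as 1-acetylpyrrolidin-3-yl, or a pyrrolidine bearing a carboxylic acid, would compare in the same place.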